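The compounds below may be only part of what the source reports. "The series", "measured", "known", "first", "only" and "open" are said of these compounds alone.

Compound 1 `O=C(NCCC1CC1)c1ccc(N2CCN(C(=O)/C=C\C(F)(F)F)CC2)nn1`: in an assay on microsomes from liver (strain ICR) for inhibition of acyl-CoA desaturase 1 (Mus musculus), read by scintillation counting, with a stated time of 20 h (a higher number here means a weaker inhibitor, a lower number a stronger inhibitor), compound 1 gives > 10000 nM, a limit of the assay.
Compound 2 `CC1CCCCC1C(=O)N1CCN(c2ccc(C(=O)NCCC3CC3)nn2)CC1`: in this assay compound 2 gives 680 nM.

Among the measured compounds shown here, compound 2 therefore stands as the only real number in this assay; the other value shown is a limit. For the measured compounds named here, the single measured step, an at least 14-fold lower number from compound 1 to compound 2 (1.16 log units; beyond the scatter), is large. Compound 3 `O=C(NCCC1CC1)c1ccc(N2CCN(C(=O)c3ccoc3C(F)(F)F)CC2)nn1` differs from compound 2 by 2-(trifluoromethyl)furan-3-yl in place of 2-methylcyclohexyl on a carbonyl carbon. The measured step exchanged an open fluorinated chain for a saturated carbocycle, whereas the step to compound 3 exchanges that carbocycle for an aromatic ring carrying a trifluoromethyl group, so the earlier step bears on it only loosely. With compound 1 at the limit of > 10000 nM in this assay, at which 1 of the 2 values shown sits, and compound 2 as the sole anchor, the expected direction is uncertain, with a moderate weakening thought more likely than a gain. Compound 3 is expected to give 2000 nM, between 500 nM and 8000 nM, a step of a 2.9-fold higher number from compound 2 to compound 3 (0.47 log units; beyond the scatter).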

Compound 3, half-maximal inhibitory concentration: 260 nM
Beside the measured number, compound 3's estimate is 7.7-fold (0.89 log units) above it, and the stated range ends above it.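

On a carbonyl carbon whose other neighbour is an amide-type nitrogen in a ring, the saturated carbocycle proves not to be needed: in this assay, 2-(trifluoromethyl)furan-3-yl in place of 2-methylcyclohexyl gives a 2.6-fold lower number from compound 2 to compound 3 (0.42 log units; beyond the scatter). Fluorine alone therefore does not settle the outcome at this position, as compound 1 and compound 3 both carry it and only compound 3 gives a real number. Putting 2-(trifluoromethyl)furan-3-yl in place of 3,3,3-trifluoroprop-1-en-1-yl gives an at least 38-fold lower number from compound 1 to compound 3 (1.58 log units; beyond the scatter), a bound rather than a measured size: the limit of > 10000 nM in this assay, at which 1 of the 3 values shown sits.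

The compounds shown leave open whether the gain belongs to the furan ring or to the trifluoromethyl group, as the two enter together. They also do not tell how a phenyl ring, an unsubstituted furan-3-yl or a 2-methylfuran-3-yl would read on this carbonyl carbon.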